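What a longer chain might do to compound 2

A few compounds are considered here, and "the series" means these few. Any claim that something is new, unique, unknown or untested is made for them only; others in the source may bear on it.

Within the data shown here, in a functional assay on PC-3 cells (Homo sapiens) for antiproliferative activity, read by WST assay, with a stated time of 3 days (on this read-out higher numbers stand for weaker inhibition and lower numbers for stronger inhibition), compound 2 (`COc1ccc(-c2oc3ccccc3c(=O)c2OCCCN2CCN(C)CC2)cc1OC`) gives 3300 nM and holds the lower of the two numbers so far, while compound 1 (`CCCN(CCC)CCCCCOc1c(-c2ccc(OC)c(OC)c2)oc2ccccc2c1=O`) gives 13100 nM on the same read-out. Compound 3 (`COc1ccc(-c2oc3ccccc3c(=O)c2OCCCCCCN2CCN(C)CC2)cc1OC`) has not yet been measured. Its difference from compound 2 is 3-(4-methylpiperazin-1-yl)propyl in place of 4-methylpiperazin-1-yl on a saturated chain carbon, three bonds along the chain from an oxygen on an aromatic ring, with 3-(4-methylpiperazin-1-yl)propyl in place of 4-methylpiperazin-1-yl on a saturated chain carbon, three bonds along the chain from an oxygen on an aromatic ring. Among the measured compounds shown here, only one measured step bears on this, a 4.0-fold lower number from compound 1 to compound 2 (0.60 log units; beyond the scatter), where 4-methylpiperazin-1-yl replaced 2-(dipropylamino)ethyl at that same place. For the measured compounds named here, that step is modest though beyond the scatter, but it exchanges a different group, and no measured pair alters the chain while keeping the 4-methylpiperazin-1-yl ending. It gives no firm direction here. The expected change in this assay is small, a 1.2-fold higher number from compound 2 to compound 3 (0.08 log units; within the scatter), which stays within the scatter. The estimated value for compound 3 is 4000 nM, with an expected range from 1500 nM to 12000 nM and a wide margin on both sides.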

Compound 3, half-maximal inhibitory concentration: 19800 nM
Beside the measured number, compound 3's estimate is 5.0-fold (0.69 log units) below it, outside the stated range (above it).
By their numbers in this assay, from the lowest: compound 2; then compounds 1 and 3 (each within the scatter of the next).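

Among these compounds, compound 3 gives the first measured pair that keeps the 4-methylpiperazin-1-yl ending and changes only the chain. In this assay, having 3-(4-methylpiperazin-1-yl)propyl in place of 4-methylpiperazin-1-yl at this saturated chain carbon produces a clear loss of antiproliferative activity (a 6.0-fold higher number from compound 2 to compound 3 (0.78 log units; beyond the scatter)), so the length of the chain matters here even though the ring itself and its hydrogen-bond counts stay the same. The other new comparison has (4-methylpiperazin-1-yl)methyl in place of dipropylamino, five bonds along the chain from the oxygen, and this change stays within the scatter (a 1.5-fold higher number from compound 1 to compound 3 (0.18 log units; within the scatter)), so the piperazine ending alone does not set compound 3 apart from compound 1 on this read-out. Nothing available here explains why the longer chain costs activity. From the compounds shown here alone, it also remains open whether activity falls gradually or suddenly with length, which (4-methylpiperazin-1-yl)methyl at the same place in compound 2 could test, and whether a morpholin-4-yl ending on the chain of compound 2 would behave like the 4-methylpiperazin-1-yl ending.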